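The compounds below may be only part of what the source reports. "The series", "measured", "known", "first", "only" and "open" are said of these compounds alone.

Measured so far in a functional assay, with a stated time of 30 min; on this read-out higher numbers stand for weaker inhibition and lower numbers for stronger inhibition:

Compound 1, `O=C(/C=C/c1cccc(O)c1)CC(=O)/C=C/c1cccc(O)c1O`: 29000 nM
Compound 2, `O=C(/C=C/c1ccc(O)cc1)CC(=O)/C=C/c1cccc(O)c1O`: 27000 nM
Compound 3, `O=C(/C=C/c1cccc(O)c1)/C=C/c1cccc(O)c1O`: 48000 nM

Of the compounds shown here, three have been tested in this assay. Compound 1 gives 29000 nM, compound 2 gives 27000 nM and compound 3 gives 48000 nM; all three numbers sit close together, and each pair lies within the usual scatter of repeated measurements. Compound 2 is compound 1 with a single change, (4-hydroxyphenyl in place of 3-hydroxyphenyl on a double-bonded chain carbon bound to a double-bonded chain carbon), and that change made a step of a 1.1-fold lower number from compound 1 to compound 2 (0.03 log units; within the scatter). Compound 1 and compound 3 are built on different cores; the difference between the two cores is not broken down here, and their two values show only that they fall within the scatter of each other.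

Compound 4, `O=C(/C=C/c1ccc(O)cc1)/C=C/c1cccc(O)c1O`, has not yet been measured. It differs from compound 3 by 4-hydroxyphenyl in place of 3-hydroxyphenyl on a double-bonded chain carbon bound to a double-bonded chain carbon, which is the same change as the one from compound 1 to compound 2; the change occurs twice among the compounds shown, at the same place each time. Among the measured compounds shown here, because the first instance of this change gave a 1.1-fold lower number from compound 1 to compound 2 (0.03 log units; within the scatter), the step of a 1.1-fold lower number from compound 3 to compound 4 (0.03 log units; within the scatter) from compound 3 to compound 4 is expected to be of about the same small size. On that basis compound 4 is estimated at 45000 nM in this assay, most likely falling between 25000 nM and 85000 nM.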

Compound 4, half-maximal inhibitory concentration: 40000 nM
Beside the measured number, compound 4's estimate is 1.1-fold (0.05 log units) above it; the measured number falls inside the stated range.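

In this assay, putting 4-hydroxyphenyl in place of 3-hydroxyphenyl on the core of compound 3 gives a 1.2-fold lower number from compound 3 to compound 4 (0.08 log units; within the scatter). Set beside the earlier instance, the change reads the same on both cores: the same change on two cores in this assay, a 1.1-fold lower number (0.03 log units; within the scatter) from compound 1 to compound 2 and a 1.2-fold lower number (0.08 log units; within the scatter) from compound 3 to compound 4, 1.1-fold (0.05 log units) apart, within the scatter of two such steps. This shows that, across these two cores, the change carried over with no step beyond the scatter in either case; it does not show that the change has any real effect on inhibition, and since neither step stands clear of the scatter, this is agreement between two small steps rather than a sizeable effect seen to transfer, and it says nothing about any core outside these two.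

The compounds shown leave open whether another group at this place on a double-bonded chain carbon, such as a methoxy group, an amine or a carboxylic acid, would give a step beyond the scatter on either core, and whether such a step would then carry from one core to the other. They also leave open what a change to the other aromatic ring would do, since that ring is the same in all four compounds.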